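Aromatic Replacement of the Pentyl Chain in a Nucleoside Series

The source may report more compounds than this note shows. Statements on the series, on what has been measured and on what is new or still open speak of the compounds shown alone.

Compound 1 `CCCCCNc1ncnc2c1ncn2[C@@H]1O[C@H](CO)[C@@H](O)[C@H]1O` carries a pentylamino group on the core and, in an assay on isolated protein for binding affinity to Equilibrative nucleoside transporter 1 (Homo sapiens) (on this read-out lower numbers stand for stronger inhibition and higher numbers for weaker inhibition), compound 1 gives 13500 nM. Compound 2 `OC[C@H]1O[C@@H](n2cnc3c(CSc4cccc(I)c4)ncnc32)[C@H](O)[C@@H]1O` instead bears a 3-iodophenyl group joined through a methylthio link to the aromatic carbon, and in this assay compound 2 gives 245 nM. For the measured compounds named here, the single step between them is a 55-fold lower number from compound 1 to compound 2 (1.74 log units; beyond the scatter). Among the two numbers, compound 1 stands highest, with compound 2 the nearer and lower one.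

Compound 3 `O=[N+]([O-])c1ccc(CNc2ncnc3c2ncn3[C@@H]2O[C@H](CO)[C@@H](O)[C@H]2O)c(Cl)c1` is the target: relative to compound 1 the change is 2-chloro-4-nitrophenyl in place of butyl on a saturated chain carbon bound to a nitrogen on an aromatic ring. Going by the values given here, the only measured step that bears on this move is a 55-fold lower number from compound 1 to compound 2 (1.74 log units; beyond the scatter), which also swaps an open chain for a six-membered aromatic ring of carbon only on the same side of the core, though through a different link and with a different substituent. On that basis a large step toward lower numbers is expected, a 45-fold lower number from compound 1 to compound 3 (1.65 log units; beyond the scatter). Compound 3 is therefore estimated at 300 nM in this assay, within a range of 30 nM to 3000 nM.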

Compound 3, half-maximal inhibitory concentration: 347 nM
Beside the measured number, compound 3's estimate is 1.2-fold (0.06 log units) below it; low and high end bracket the measured number.
By their numbers in this assay, from the lowest: compounds 2 and 3 (each within the scatter of the next); then compound 1.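

With the nitrogen on the core and the saturated chain carbon bound to it held in place, 2-chloro-4-nitrophenyl in place of butyl gives a 39-fold lower number from compound 1 to compound 3 (1.59 log units; beyond the scatter) in this assay and shows that a large step can arise at this position through the end of the chain alone. The earlier step, a 55-fold lower number from compound 1 to compound 2 (1.74 log units; beyond the scatter), changed the link to the core together with the group at its end, so it could not show whether a change confined to the far end of the chain was enough. Compound 3 contains neither sulfur nor iodine, so among the compounds shown, neither atom is required for a number far lower than that of compound 1, and no measured property of these groups is available to explain the step.

The new step brings in the six-membered aromatic ring, the chlorine and the nitro group all at once, so the share of each cannot be read from these compounds. Going by these compounds, it remains open how an unsubstituted phenyl group would compare, or how the number would respond to a methoxy group or an amine in place of the nitro group.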